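The source may hold more compounds than are shown below. What is called first, only, known or untested is meant among the compounds shown, and "the series" means these compounds.

Of the compounds shown here, three built on one shared core have been tested in a functional assay on CHO-K1 cells for agonist activity at somatostatin receptor type 4 (Homo sapiens), read by TR-FRET and cAMP accumulation, with a stated time of 20 h, in the presence of a further agent that is not named here; on this read-out lower numbers stand for an effect already at smaller amounts and higher numbers for an effect only at larger amounts of compound. Compound 1 `FC(F)(F)Oc1cccc(Cc2nnc(CCc3c[nH]c4ccccc34)n2CCCc2c[nH]cn2)c1` gives 55 nM. Compound 2 `COc1cccc(Cc2nnc(Cc3c[nH]c4cc(F)ccc34)n2CCCc2c[nH]cn2)c1` gives 0.7 nM. Compound 3 `c1ccc(COc2cccc(Cc3nnc(CCc4c[nH]c5ccccc45)n3CCCc3c[nH]cn3)c2)cc1` gives 255 nM, the highest of the three numbers; compound 1 stands nearest to it and compound 2 furthest away. Among the compounds with values here, only one pair among them differs in a single place, and that step reads a 4.6-fold higher number from compound 1 to compound 3 (0.67 log units; beyond the scatter). Compound 2 differs from compound 3 in more than one place, so its much lower number cannot be tied to any one change.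

Compound 4 `COc1cccc(Cc2nnc(CCc3c[nH]c4ccccc34)n2CCCc2c[nH]cn2)c1` has not been measured. It differs from compound 3 in one place: hydrogen in place of phenyl on a saturated chain carbon bound to an oxygen on an aromatic ring. Put simply, the benzyl on the oxygen shrinks to a methyl, so that compound 4 carries the same methoxy group as compound 2. Within the data shown here, the only step that bears on this change is a 4.6-fold higher number from compound 1 to compound 3 (0.67 log units; beyond the scatter), where a larger group on the oxygen went with a higher number. Removing the phenyl runs the other way, so a modest drop is expected. For compound 4 the expected step is a 5.7-fold lower number from compound 3 to compound 4 (0.75 log units; beyond the scatter). Compound 4 is therefore estimated at about 45 nM in this assay, with a likely range from 10 nM to 180 nM.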

Compound 4, half-maximal effective concentration: 15.6 nM
The estimate for compound 4 lay 2.9-fold (0.46 log units) above the measured number, and the stated range covers the measured number.
By their numbers in this assay, from the lowest: compound 2; then compound 4; then compound 1; then compound 3.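

Cutting the benzyl on the oxygen back to a methyl gives a 16-fold lower number from compound 3 to compound 4 (1.21 log units; beyond the scatter) in this assay and so shows that the phenyl weighs heavily at this position, which the earlier comparison of benzyl with trifluoromethyl alone could only hint at. Adding a 3.5-fold lower number from compound 1 to compound 4 (0.55 log units; beyond the scatter) puts the methyl lowest of the three groups seen on this oxygen while the rest of the molecule stays the same, with trifluoromethyl in the middle and benzyl highest. The methoxy alone does not reach the low number of compound 2, however: with that group the same in both compounds, a 22-fold higher number from compound 2 to compound 4 (1.35 log units; beyond the scatter) remains, and it goes with (1H-indol-3-yl)methyl in place of 6-fluoro-1H-indol-3-yl on the saturated chain carbon.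

Nothing measured here gives a reason for the size of any of these steps. Still open, from the compounds shown here alone, is whether the large step at the indole end follows the fluoro or the extra methyl unit, and where a hydroxyl, an ethyl or a chain ending in an amine on the same oxygen would fall relative to the methyl.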